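A few compounds are considered here, and "the series" means these few. Any claim that something is new, unique, unknown or untested is made for them only; others in the source may bear on it.

Measured in an ADME assay on microsomes from liver (Mus musculus, strain CD1) for metabolic stability, read by HPLC, using NADPH, with a stated time of 30 min; a higher number here means faster removal of the compound, a lower number slower removal:
- compound 1 `COc1cccc(NC(=O)c2nnn(Cc3ccc([S+](C)[O-])cc3)c2N)c1`: 0.5 mL.min-1.g-1
- compound 2 `COc1cccc(NC(=O)c2nnn(CC3CCNCC3)c2N)c1`: < 0.5 mL.min-1.g-1 (a limit)

The reading for compound 2 is a limit and not a number, < 0.5 mL.min-1.g-1. Compound 3 `COc1cccc(NC(=O)c2nnn(Cc3ccccc3)c2N)c1` differs from it by phenyl in place of piperidin-4-yl on a saturated chain carbon bound to an aromatic nitrogen, with phenyl in place of piperidin-4-yl on a saturated chain carbon bound to an aromatic nitrogen. For the measured compounds named here, only one measured step bears on this change, a number no higher from compound 1 to compound 2 (the limit leaves the size open), and its size cannot be read. Compound 1, which has a six-membered aromatic ring on that carbon, gives 0.5 mL.min-1.g-1, so a rise in this assay is expected, of uncertain size. The expected step is an at least 6.0-fold higher number from compound 2 to compound 3 (0.77 log units; beyond the scatter). For compound 3 the estimated value is 3 mL.min-1.g-1, with an expected range from 0.7 mL.min-1.g-1 to 12 mL.min-1.g-1.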

Compound 3, intrinsic clearance in microsomes: 3.7 mL.min-1.g-1
Estimate against measurement, compound 3: 1.2-fold (0.09 log units) below; the range from low to high includes it.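

In this assay the phenyl group gives the first readable rise at this position, with phenyl in place of piperidin-4-yl on a saturated chain carbon bound to an aromatic nitrogen: an at least 7.4-fold higher number from compound 2 to compound 3 (0.86 log units; beyond the scatter). Compound 2 stands at a limit and not a number, so this step has no upper size: the limit of < 0.5 mL.min-1.g-1 in this assay, at which 1 of the 3 values shown sits. A hydrogen atom in place of the sulfur-bearing group on the aromatic carbon gives a 7.4-fold higher number from compound 1 to compound 3 (0.87 log units; beyond the scatter), so the aromatic ring alone does not fix the reading. Open, going by these compounds, is whether an amine or a carboxylic acid on that aromatic carbon would also hold the number down, and what a longer chain would do.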